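The source may report more compounds than this note shows. Statements on the series, on what has been measured and on what is new or still open speak of the compounds shown alone.

Working notes on the series in a functional assay on MKN-45 cells (Homo sapiens) for cytotoxicity; a lower number here means a stronger inhibitor, a higher number a weaker inhibitor.

Of the compounds shown here, three of the shared core have been measured. Compound 1 `COc1ccc(S(=O)(=O)N2CCc3cccc(NC(=O)c4ccc([N+](=O)[O-])cc4)c32)cc1` gives 95 nM in this assay. Compound 2 `COc1ccc(S(=O)(=O)N2CCc3cccc(NC(=O)c4ccncc4)c32)cc1` gives 8.8 nM. Among the measured compounds shown here, compound 3 `COc1ccc(C(=O)Nc2cccc3c2N(S(=O)(=O)c2ccc(OC)cc2)CC3)cc1` gives 1600 nM, the highest number of the three, so compound 3 is the weakest compound measured so far; its nearest neighbour by number is compound 1 and its furthest is compound 2. The steps between them are all large: an 11-fold lower number from compound 1 to compound 2 (1.03 log units; beyond the scatter), a 17-fold higher number from compound 1 to compound 3 (1.23 log units; beyond the scatter) and a 180-fold higher number from compound 2 to compound 3 (2.26 log units; beyond the scatter). The group on the carbonyl carbon thus moves the number by a wide margin in this series.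

Compound 4 `COc1ccc(S(=O)(=O)N2CCc3cccc(NC(=O)c4ccco4)c32)cc1` is not yet measured. It differs from compound 3 in one place: furan-2-yl in place of 4-methoxyphenyl on a carbonyl carbon. The step that bears most directly on it is the swap of that same group, a 180-fold higher number from compound 2 to compound 3 (2.26 log units; beyond the scatter), which shows that replacing 4-methoxyphenyl by a heteroaryl ring there can lower the number by a large step; compound 1 also sits well under compound 3. A five-membered heteroaryl has not been tested, so the size is uncertain, but a step downward beyond the scatter is expected, an 11-fold lower number from compound 3 to compound 4 (1.03 log units; beyond the scatter). Compound 4 is estimated at 150 nM, within 30 nM to 800 nM.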

Compound 4, half-maximal inhibitory concentration: 10.7 nM
The estimate for compound 4 lay 14-fold (1.15 log units) above the measured number; measured number below the stated range.
By their numbers in this assay, from the lowest: compounds 2 and 4 (each within the scatter of the next); then compound 1; then compound 3.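

In this assay, the low number at this carbonyl carbon is not confined to pyridin-4-yl, as furan-2-yl matches it (a 1.2-fold higher number from compound 2 to compound 4 (0.08 log units; within the scatter)), so a five-membered aromatic ring with one hetero atom serves there as well as the six-membered heteroaryl. Against the two phenyl-bearing compounds, the change gives a large step from 4-methoxyphenyl (a 150-fold lower number from compound 3 to compound 4 (2.17 log units; beyond the scatter)) and a modest one from 4-nitrophenyl (an 8.9-fold lower number from compound 1 to compound 4 (0.95 log units; beyond the scatter)), so in these four compounds both heteroaryl groups sit under both substituted phenyl groups. Nothing measured here explains this split.

Open, going by these compounds, is whether the hetero atom in the ring is what matters, since an unsubstituted phenyl or a thiophene on the carbonyl carbon would test that. A saturated ring such as piperidine at this place also remains to be read.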